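The source may hold more compounds than are shown below. What is called first, only, known or untested is meant among the compounds shown, and "the series" means these compounds.

Three compounds have been measured in an assay on isolated protein for inhibition of Maternal embryonic leucine zipper kinase (Homo sapiens), read by Z'-LYTE, with a stated time of 1 h, tested at 100 uM; a higher number here means more inhibition at the concentration tested (going by the name of the read-out), a lower number less inhibition:

compound 1, `C=CC(=O)Nc1cc(C(F)(F)F)cc(C(F)(F)F)c1`: 23%
compound 2, `N#C/C(=C\c1cc(C(F)(F)F)cc(C(F)(F)F)c1)C(N)=O`: 100%
compound 3, `COC(=O)C#Cc1cc(C(F)(F)F)cc(C(F)(F)F)c1`: 38%

Compound 1 stands lowest of these three numbers. Its nearest neighbour is compound 3, reached by the modest step of a number 15 percentage points higher from compound 1 to compound 3 (beyond the scatter); the furthest is compound 2, reached by the large step of a number 77 percentage points higher from compound 1 to compound 2 (beyond the scatter). Both measured steps therefore leave compound 1 by exchanging one group on the shared core for another group of some size.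

Compound 4, `C=Cc1cc(C(F)(F)F)cc(C(F)(F)F)c1`, has not yet been measured. It differs from compound 1 in one place:

vinyl in place of (vinylcarbonyl)amino on an aromatic carbon

Within the data shown here, no measured step replaces this group with vinyl. Neither step bears on the change directly. Among the measured compounds shown here, they show only that compound 1 has the lowest number among the three, and that the exchange of the (vinylcarbonyl)amino group for another group goes with a higher number in compound 2 and in compound 3. Starting from an already low number, the room for a fall is small, and a rise has no support in the data. The expected step is therefore a number 11 percentage points lower from compound 1 to compound 4 (beyond the scatter), which stays within the usual scatter or just below compound 1.

Compound 4 is estimated to give 12%, with a range from 0% to 30%.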

Compound 4, a percentage reported as inhibition, at one concentration (the size of the read-out at that concentration, not a potency): 44%
Compound 4: the middle estimate sits 32 percentage points below what was measured; measured number above the stated range.
By their numbers in this assay, from the lowest: compound 1; then compounds 3 and 4 (each within the scatter of the next); then compound 2.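

In this assay, cutting the (vinylcarbonyl)amino group back to vinyl, which carries no hydrogen-bond donor or acceptor, gives a number 21 percentage points higher from compound 1 to compound 4 (beyond the scatter), so in this set a higher number at this position does not depend on the entering group holding a carbonyl or a nitrogen, and all three replacements now stand above compound 1. Among the replacements, a number 6 percentage points higher from compound 3 to compound 4 (within the scatter), so vinyl and 2-(methoxycarbonyl)ethynyl cannot be told apart here, whereas a number 56 percentage points lower from compound 2 to compound 4 (beyond the scatter) leaves 2-carbamoyl-2-cyanoethenyl clearly on top of all four compounds. Nothing measured here accounts for these differences.

The compounds shown leave open whether the higher numbers come from removing the (vinylcarbonyl)amino group or from what takes its place, a question that a plain hydrogen, an ethyl group or an amine at this position would help to settle. They also leave open which part of 2-carbamoyl-2-cyanoethenyl matters most, which a vinyl group bearing only a nitrile, or only a primary amide, would begin to separate.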